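Nitro in place of chloro in a cytotoxicity series

The compounds below may be only part of what the source reports. "The series", "measured", "known", "first", "only" and "open" are said of these compounds alone.

Three compounds sharing one core were measured in an ADME assay on Vero cells (Chlorocebus sabaeus) for cytotoxicity, read by neutral red uptake, tested at 787 ug/mL; a lower number here means a stronger effect, a higher number a weaker effect of the compound at the concentration tested. Compound 1 `O=C1CSC(c2cccc(F)c2)N1CCN1CCCCC1` gives 27%, compound 2 `O=C1CSC(c2ccc(Cl)cc2)N1CCN1CCCCC1` gives 15%, and compound 3 `COc1cccc(C2SCC(=O)N2CCN2CCCCC2)c1` gives 19%. Compound 2 therefore sits lowest of the three numbers; the gap to compound 3 is within the scatter, while the step of a number 12 percentage points lower from compound 1 to compound 2 (beyond the scatter) lies beyond it. The change of methoxy in place of fluoro gave a number 8 percentage points lower from compound 1 to compound 3 (within the scatter).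

Compound 4 `O=C1CSC(c2ccc([N+](=O)[O-])cc2)N1CCN1CCCCC1` differs from compound 2 by nitro in place of chloro on an aromatic carbon. Within the data shown here, no measured step swaps these two groups, so neither the chloro step nor the methoxy step speaks directly to it; both only show that changes on this aromatic ring moved this assay by a modest amount or stayed within the scatter. The expectation for compound 4 is accordingly a step of a number 5 percentage points higher from compound 2 to compound 4 (within the scatter), close to no change beyond the scatter. Compound 4 is estimated at 20%, within a range from 8% to 36%.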

Compound 4, a percentage reported as activity, at one concentration (the size of the read-out at that concentration, not a potency): 21%
Estimate against measurement, compound 4: 1 percentage points below; the range from low to high includes it.
By their numbers in this assay, from the lowest: compounds 2, 3, 4 and 1 (each within the scatter of the next, the first and the last beyond it).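

In this assay, nitro in place of chloro on an aromatic carbon, para to a large group, gives a number 6 percentage points higher from compound 2 to compound 4 (within the scatter) and so does not separate the two groups at this place. The earlier steps shown here all started from the 3-fluorophenyl compound, whereas this one keeps the place on the ring fixed and changes only the group there. At this position, a nitro group, which carries hydrogen-bond acceptors and more heavy atoms than chloro, therefore leaves the read-out within the scatter, though nothing available explains this result.

As far as these compounds go, it remains open whether an amine or a carboxylic acid at the same place would also stay within the scatter. The compounds shown also do not tell whether nitro would read the same elsewhere on the aromatic ring.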